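From methyl to chloro on the pendant phenyl ring

The compounds below may be only part of what the source reports. "The series", "measured", "known", "first", "only" and "open" are said of these compounds alone.

Measured in a functional assay on B16 cells (Mus musculus) for cytotoxicity, read by MTT assay, with a stated time of 72 h; a lower number here means a stronger inhibitor, a higher number a weaker inhibitor:
compound 1 `COc1ccc(-c2cc(=O)c3c(O)cc(OCCCCN4CCN(C)CC4)c(OC)c3o2)cc1` gives 4100 nM
compound 2 `COc1c(OCCCCN2CCN(C)CC2)cc(O)c2c(=O)cc(-c3ccc(C)cc3)oc12` gives 5430 nM

Among the compounds with values here, compound 2 carries the higher number of the two, but its only neighbour, compound 1, sits within the scatter of it: the step of a 1.3-fold higher number from compound 1 to compound 2 (0.12 log units; within the scatter) is too small to count as a difference. The pair therefore shows only that methyl in place of methoxy on the aromatic carbon left the result where it was.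

Compound 3 `COc1c(OCCCCN2CCN(C)CC2)cc(O)c2c(=O)cc(-c3ccc(Cl)cc3)oc12` has not yet been measured in this assay. It differs from compound 2 by chloro in place of methyl on an aromatic carbon. Within the data shown here, no measured step makes this particular exchange; the one step that alters the same aromatic carbon, a 1.3-fold higher number from compound 1 to compound 2 (0.12 log units; within the scatter), stayed within the scatter, and compound 1 and compound 2 together give no sign that the group there sets the outcome. A step no larger than the scatter, in no particular direction, is therefore expected, and compound 3 is estimated at 5000 nM, with a range from 2500 nM to 10000 nM. That estimate corresponds to a step of a 1.1-fold lower number from compound 2 to compound 3 (0.04 log units; within the scatter).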

Compound 3, half-maximal inhibitory concentration: 2090 nM
Estimate against measurement, compound 3: 2.4-fold (0.38 log units) above; measured number outside the range, below it.
By their numbers in this assay, from the lowest: compounds 3, 1 and 2 (each within the scatter of the next, the first and the last beyond it).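

In this assay, within the data shown here, the change from 4-methylphenyl to 4-chlorophenyl gives the first step at this aromatic carbon that exceeds the scatter: a 2.6-fold lower number from compound 2 to compound 3 (0.41 log units; beyond the scatter). Among these compounds, the group here can therefore alter the result, which the pair of compound 1 and compound 2 gave no sign of, although the effect is modest and only this one exchange shows it. Chloro in place of methoxy gives a 2.0-fold lower number from compound 1 to compound 3 (0.29 log units; within the scatter), which stays within the scatter, so compound 3 separates from compound 2 but not from compound 1, and the three groups do not form a clear order. Nothing given here accounts for the difference between chloro and methyl.

The compounds shown leave open whether fluoro, bromo, a nitrile or an amine on this carbon would move the number further, or return it to the level of compound 2. They also leave open whether the difference between chloro and methyl would persist with a shorter or longer chain on the shared core, since every compound here carries the same chain.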